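Chain shortening on the dichlorophenyl amide at a limit

This account rests on a few compounds, and the source may have more. Where it says the series, first, only, none or still open, it means among the compounds named here.

Compound 3 `C=CC1=C(C(=O)NCCCCC)C(c2ccc(Cl)c(Cl)c2)OC1` carries a pentyl chain on the amide nitrogen. In a functional assay on HeLa cells (Homo sapiens) for cytotoxicity, read by MTT assay, with a stated time of 24 h (on this read-out lower numbers stand for stronger inhibition and higher numbers for weaker inhibition), compound 3 gives only a limit, > 100000 nM. The two further values shown are limits as well. In this assay compound 1 `C=CC1=C(C(=O)NCCC)C(c2ccc(F)cc2)OC1` gives > 100000 nM, a limit. In this assay compound 2 `C=CC1=C(C(=O)NCc2ccc(C)cc2)C(c2ccc(F)cc2)OC1` gives > 100000 nM, again a limit. The step that the two limits leave unreadable from compound 1 to compound 2 is therefore unreadable, and every value shown sits at the limit of > 100000 nM in this assay, at which 3 of the 3 values shown sit.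

Compound 4 `C=CC1=C(C(=O)NCCC)C(c2ccc(Cl)c(Cl)c2)OC1` differs from compound 3 by hydrogen in place of ethyl on a saturated chain carbon, three bonds along the chain from an amide-type nitrogen. Going by the values given here, no measured step bears directly on this change: the only step available, a step that the two limits leave unreadable from compound 1 to compound 2, concerns the other substituent on the amide nitrogen and has no readable size. Among the compounds with values here, the series so far shows no compound reaching a number in this assay, and compound 1 with the propyl amide sits at the same limit as the longer chains.

For compound 4 in this assay the expected value is 200000 nM, with a range from 60000 nM to 600000 nM. The estimate means a step that the limit leaves unreadable from compound 3 to compound 4, expected to stay within the scatter, most likely as a further limit.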

Compound 4, half-maximal inhibitory concentration: > 100000 nM
Compound 4 gave a limit, no number (the forecaster's own chance of this, stated with the estimate: 85%); the middle value is on the limit's open side.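

No step can be read from compound 3 to compound 4, as both give only limits in this assay: the limit of > 100000 nM in this assay, at which 4 of the 4 values shown sit.

The compounds shown leave open whether any change to the amide chain or the halogenated phenyl group on the shared core would give a readable number in this assay.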